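The source may report more compounds than this note shows. Statements on the series, on what has been measured and on what is new or still open speak of the compounds shown alone.

Working notes on the series

Three members of the series have been measured in a functional assay on BCG823 cells (Homo sapiens) for inhibition, read by MTT assay, with a stated time of 72 h; on this read-out lower numbers stand for stronger inhibition and higher numbers for weaker inhibition; the three share a common core and differ in the group on one aromatic carbon of the five-membered ring and in the aryl part of the hydrazone.

Compound 3 `CN(C(=O)NC(=O)c1c(F)cccc1F)c1nc(C(F)(F)F)c(C(=O)N/N=C/c2cc(C(F)(F)F)cc(C(F)(F)F)c2)s1` gives 5.28 ug/mL in this assay. Compound 1 `Cc1nc(N(C)C(=O)NC(=O)c2c(F)cccc2F)sc1C(=O)N/N=C/c1cc(C(F)(F)F)cc(C(F)(F)F)c1` differs from compound 3 only by methyl in place of trifluoromethyl on an aromatic carbon; in this assay compound 1 gives 14.1 ug/mL, and the step is a 2.7-fold higher number from compound 3 to compound 1 (0.43 log units; beyond the scatter), a weakening.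

Compound 2 `CN(C(=O)NC(=O)c1c(F)cccc1F)c1nc(C(F)(F)F)c(C(=O)N/N=C/c2ccc(C(F)(F)F)cc2)s1` gives 34.9 ug/mL in this assay, the highest number of the three and beyond the scatter from both compound 1 and compound 3. The difference between the core of compound 2 and the core of compound 3 is not broken down here.

Compound 4 `Cc1nc(N(C)C(=O)NC(=O)c2c(F)cccc2F)sc1C(=O)N/N=C/c1ccc(C(F)(F)F)cc1` has not yet been measured. It differs from compound 2 by methyl in place of trifluoromethyl on an aromatic carbon. The place of this change is described in the same words as for the pair compound 3 to compound 1, so it is the same change, made twice in all among the compounds shown. Since compound 2 already stands at the weak end of the series, the step is expected to fall in the same direction and of a similar size as a 2.7-fold higher number from compound 3 to compound 1 (0.43 log units; beyond the scatter), giving an expected 2.6-fold higher number from compound 2 to compound 4 (0.41 log units; beyond the scatter); this rests on a single prior instance on a core that is not identical, so the range is kept wide. Compound 4 is therefore estimated at 90 ug/mL, with the likely span running from 40 ug/mL to 200 ug/mL.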

Compound 4, half-maximal inhibitory concentration: 65.5 ug/mL
The estimate for compound 4 lay 1.4-fold (0.14 log units) above the measured number; low and high end bracket the measured number.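

Working from the same change on the second core, methyl in place of trifluoromethyl on the aromatic carbon gives a 1.9-fold higher number from compound 2 to compound 4 (0.27 log units; within the scatter) in this assay, and set beside the first instance the two steps do not separate: the same change on two cores in this assay, a 2.7-fold higher number (0.43 log units; beyond the scatter) from compound 3 to compound 1 and a 1.9-fold higher number (0.27 log units; within the scatter) from compound 2 to compound 4, 1.4-fold (0.15 log units) apart, within the scatter of two such steps

Within this small set, the change therefore carries from the core of compound 3 to the core of compound 2 with no difference that can be told from the scatter, and both steps point the same way, although the new step taken alone does not stand clear of the scatter. For the compounds shown here, this does not show a fixed increment for the change: there are only two pairs, both in one assay and both with trifluoromethyl on the aryl part of the hydrazone, so nothing here extends to a hydrazone aryl part of another kind.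

The compounds shown leave open what a hydrogen, a chlorine, an ethyl or a nitrile on that ring carbon would give, since only methyl and trifluoromethyl appear there. They also leave open how the step behaves with a methoxy group, an amine or a carboxylic acid on the hydrazone aryl part, or with a different group in place of the shared difluorobenzoyl end.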